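The source may hold more compounds than are shown below. What is called first, only, known or untested is meant among the compounds shown, and "the series" means these compounds.

In an ADME assay on cells (Peritoneal macrophage, Mus musculus) for cytotoxicity, read by MTT assay, with a stated time of 24 h (a higher number here means that more compound is tolerated, a lower number that less compound is tolerated), compound 1 `CC(C)(C)c1ccc(N/C(=N\C(=O)c2ccccc2)NCc2ccccc2)cc1`, which carries tert-butyl, gives 1120000 nM. Compound 2 `O=C(/N=C(/NCc1ccccc1)Nc1ccc(F)cc1)c1ccccc1`, which carries fluoro, gives 866000 nM, and compound 3 `O=C(/N=C(/NCc1ccccc1)Nc1ccccc1)c1ccccc1`, with hydrogen in place of fluoro, gives 35900 nM. Compound 2 stands close to compound 1: a 1.3-fold lower number from compound 1 to compound 2 (0.11 log units; within the scatter). The other two steps are both large: a 24-fold lower number from compound 2 to compound 3 (1.38 log units; beyond the scatter) and a 31-fold lower number from compound 1 to compound 3 (1.49 log units; beyond the scatter).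

Compound 4 `O=C(/N=C(/NCc1ccccc1)Nc1ccc(I)cc1)c1ccccc1` changes compound 2 in one place: iodo in place of fluoro on an aromatic carbon, para to a large group. For the measured compounds named here, no measured step exchanges one halogen for another, so the evidence is indirect. The expectation rests on compound 1 and compound 2, two different groups that fall together in the step of a 1.3-fold lower number from compound 1 to compound 2 (0.11 log units; within the scatter). Only compound 3, the case with hydrogen, lies far from them. Three compounds are a thin basis, so the range is kept wide. The expected step, a 1.3-fold lower number from compound 2 to compound 4 (0.12 log units; within the scatter), is an estimate of no real change beyond the scatter. For compound 4 the estimated value is 650000 nM, with an expected range from 150000 nM to 1500000 nM.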

Compound 4, half-maximal cytotoxic concentration: 619000 nM
Compound 4: middle estimate off by 1.1-fold (0.02 log units), on the high side, and the stated range covers the measured number.
By their numbers in this assay, from the lowest: compound 3; then compounds 4, 2 and 1 (each within the scatter of the next).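

In this assay, the exchange of one halogen for another on this aromatic carbon, para to a large group, can now be read directly: a 1.4-fold lower number from compound 2 to compound 4 (0.15 log units; within the scatter), so fluoro and iodo cannot be told apart here. Iodo also falls with tert-butyl, a 1.8-fold lower number from compound 1 to compound 4 (0.26 log units; within the scatter), while the step from the hydrogen case is large, a 17-fold higher number from compound 3 to compound 4 (1.24 log units; beyond the scatter), so three different groups now sit together and compound 3 alone stands apart. Nothing measured here gives a reason for that gap.

From the compounds shown here alone, it remains open whether the gap from hydrogen would hold for an amine, a methoxy group or a carboxylic acid at this position. The compounds shown also leave open whether it would persist with any change elsewhere in the shared core.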